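A few compounds are considered here, and "the series" means these few. Any claim that something is new, unique, unknown or untested is made for them only; others in the source may bear on it.

In a physicochemical assay for lipophilicity, read by HPLC, with a stated time of 90 min, tested at 100 uM (a lower number here means a more polar compound, a higher number a more lipophilic compound), compound 1 `Cc1occc1C(=O)N1CCC(NC(=O)Nc2ccc(C(F)(F)F)cc2)CC1` gives 4.19, and compound 2 `Cc1occc1C(=O)N1CCC(NC(=O)Nc2ccc(OC(F)(F)F)cc2)CC1` gives 4.3, so these two sit within the scatter of each other. Compound 3 `O=C(Nc1ccc(C(F)(F)F)c(F)c1)NC1CCN(C(=O)C2(C(F)(F)F)CC2)CC1` stands well apart at 5.52, the furthest from compound 1 and beyond the scatter.

Compound 4 `O=C(Nc1ccc(C(F)(F)F)cc1)NC1CCN(C(=O)C2CCOCC2)CC1` has not yet been measured. It differs from compound 1 in a single place: oxan-4-yl in place of 2-methylfuran-3-yl on a carbonyl carbon. In words, oxan-4-yl stands in place of 2-methylfuran-3-yl on a carbonyl carbon, so a five-membered aromatic ring gives way to a six-membered non-aromatic ring.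

Within the data shown here, the only measured single-change step is a number 0.11 log units higher from compound 1 to compound 2 (within the scatter). That step is trifluoromethoxy in place of trifluoromethyl on an aromatic carbon, so it says nothing directly about a change on the carbonyl carbon. Compound 3 differs from compound 1 in more than one place, so its value cannot size this change either.

The expectation therefore rests on the nature of the swap alone, and it carries a wide margin. A move to a lower number in this assay is expected, probably beyond the scatter. The estimated step is a number 0.59 log units lower from compound 1 to compound 4 (beyond the scatter). Compound 4 is expected at 3.6, with an estimated range from 3.1 to 4.1.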

Compound 4, partition coefficient: 3.16
Compound 4: middle estimate off by 0.44 log units, on the high side; measured number inside the range.
By their numbers in this assay, from the lowest: compound 4; then compounds 1 and 2 (each within the scatter of the next); then compound 3.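

In this assay, the group on the carbonyl carbon now has a single-place step of its own, and a number 1.03 log units lower from compound 1 to compound 4 (beyond the scatter) is a clear move. Among these compounds, the only earlier step of this kind, on an aromatic carbon, was a number 0.11 log units higher from compound 1 to compound 2 (within the scatter) and stayed within the scatter, so it is this new result that first shows the number can shift substantially through a change in one place on this molecule. The shift comes with no change in the counts of heavy atoms, carbon, oxygen, hydrogen-bond donors or hydrogen-bond acceptors, so those counts do not separate 2-methylfuran-3-yl from oxan-4-yl, and what differs is one five-membered aromatic ring against one six-membered non-aromatic ring.

On these data alone, it remains open whether ring size or the aromatic ring matters more here, a question that a phenyl or cyclohexyl group on this carbonyl carbon could begin to separate, while an amine or a longer chain there would test how far the number can move. No independent measurement bears on why this step takes the size it does.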